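Flipping One Stereocentre: From Compound 2 to Compound 3

A few compounds are considered here, and "the series" means these few. Any claim that something is new, unique, unknown or untested is made for them only; others in the source may bear on it.

Of the compounds shown here, two have been measured. In an assay on brain for inhibition of sodium-dependent dopamine transporter (Rattus norvegicus) (on this read-out lower numbers stand for stronger inhibition and higher numbers for weaker inhibition), compound 1 `Clc1ccc([C@@]23CNC[C@@H]2[C@H]3c2ccccc2)cc1Cl` gives 360 nM, and compound 2 `C[C@H]1[C@H]2CNC[C@]21c1ccc(Cl)c(Cl)c1` gives 500 nM. Compound 2 thus holds the higher of the two numbers, but its distance to compound 1 lies within the scatter, so the two cannot be told apart on this read-out.

The next compound is compound 3 `C[C@@H]1[C@H]2CNC[C@@]12c1ccc(Cl)c(Cl)c1`. Its relation to compound 2 is the two compounds have the same atoms and bonds and differ only in configuration as drawn: 1 of 3 stereo elements differ; a stereocentre at a saturated ring carbon is drawn S in compound 2 and R in compound 3: the same atoms and bonds, with only one stereocentre at a saturated ring carbon drawn the other way. Within the data shown here, no measured pair differs by such a flip, so there is no measured step to lean on; a change in configuration may leave the number where it is or move it far in either direction.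

Compound 3 is therefore expected to give 600 nM, within a range from 150 nM to 2500 nM. The expected step is a 1.2-fold higher number from compound 2 to compound 3 (0.08 log units; within the scatter), none beyond the scatter, with wide uncertainty.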

Compound 3, half-maximal inhibitory concentration: 400 nM
Compound 3: the middle estimate sits 1.5-fold (0.18 log units) above what was measured; the range from low to high includes it.
By their numbers in this assay, from the lowest: compounds 1, 3 and 2 (each within the scatter of the next).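

Among these compounds, until now, no measured pair showed what a flip at this stereocentre does: in this assay, drawing a stereocentre at a saturated ring carbon the other way gives a 1.3-fold lower number from compound 2 to compound 3 (0.10 log units; within the scatter). That step can be tied to this one stereocentre alone: the fact that compounds 2 and 3 differ only in the configuration as drawn. Methyl in place of phenyl on a saturated ring carbon gives a 1.1-fold higher number from compound 1 to compound 3 (0.05 log units; within the scatter), so this change also leaves no mark beyond the scatter on this read-out.

On these data alone, it remains open whether flipping either of the other two stereo elements would be just as silent in this assay. As far as these compounds go, it is also open how an ethyl group, a longer chain or a hydroxymethyl group would read in place of the methyl on this saturated ring carbon, and whether the flip would still leave the number within the scatter with such a group in place.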